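Small Steps on the Oxygen Substituent

The compounds below may be only part of what the source reports. "The series", "measured", "known", "first", "only" and "open" are said of these compounds alone.

- Compound 1 `CC(C)CCOc1ccccc1C1CC(=O)c2ccccc2O1` gives 39200 nM here
- Compound 2 `CC(C)COc1ccccc1C1CC(=O)c2ccccc2O1` gives 36700 nM here
- Compound 3 `O=C1CC(c2ccccc2OCc2ccccc2)Oc2ccccc21` gives 18900 nM here

All three values come from a functional assay on RAW264.7 cells (Mus musculus) for inhibition, read by Griess assay, with stated times of 1 h and 24 h (a lower number here means a stronger inhibitor, a higher number a weaker inhibitor), and the compounds differ only in the group on one oxygen. Among the alkyl groups the measured change is a 1.1-fold lower number from compound 1 to compound 2 (0.03 log units; within the scatter) and so shows nothing real. With benzyl the record shows a 2.1-fold lower number from compound 1 to compound 3 (0.32 log units; beyond the scatter) and also a 1.9-fold lower number from compound 2 to compound 3 (0.29 log units; within the scatter) so compound 3 stands clear of compound 1 but not of compound 2.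

Compound 4 `O=C1CC(c2ccccc2O)Oc2ccccc21` has not been measured. It differs from compound 3 by hydrogen in place of benzyl on an oxygen on an aromatic ring, or benzyloxy to hydroxy. The measured steps change this same group, yet none removes it, so they guide only loosely. All are small, and the largest, a 2.1-fold lower number from compound 1 to compound 3 (0.32 log units; beyond the scatter) favours benzyl only modestly. Losing benzyl is therefore expected to give a small move towards a higher number, perhaps none beyond the scatter, and the estimated step is a 1.6-fold higher number from compound 3 to compound 4 (0.20 log units; within the scatter) in this reading. For compound 4 the estimate is 30000 nM (expected range 12000 nM to 70000 nM).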

Compound 4, half-maximal inhibitory concentration: 71300 nM
The estimate for compound 4 lay 2.4-fold (0.38 log units) below the measured number, and the stated range ends below it.
By their numbers in this assay, from the lowest: compounds 3, 2, 1 and 4 (each within the scatter of the next, the first and the last beyond it).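

In this assay, for the compounds shown here, replacing benzyl with hydrogen on this oxygen gives a 3.8-fold higher number from compound 3 to compound 4 (0.58 log units; beyond the scatter), the first step in this set that removes the group outright and the largest seen here. The same replacement of the alkyl groups is less clear: isobutyl to hydrogen gives a 1.9-fold higher number from compound 2 to compound 4 (0.29 log units; within the scatter) and isopentyl to hydrogen gives a 1.8-fold higher number from compound 1 to compound 4 (0.26 log units; within the scatter), so among these groups only benzyl stands clear of the free hydroxy. Nothing available explains why benzyl separates from hydrogen when the two alkyl groups do not.

The compounds shown leave open whether the benzyl ring itself matters or whether any larger group would do. A phenylethyl group, a benzyl ring carrying a methoxy group, or a chain ending in an amine would each test this further.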